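The source may report more compounds than this note shows. Statements on the series, on what has been measured and on what is new or still open speak of the compounds shown alone.

Measured so far in a functional assay on muscle tissue for agonist activity at histamine H2 receptor (Cavia porcellus); on this read-out lower numbers stand for smaller maximal responses and higher numbers for larger maximal responses:

- compound 1 `COc1ccc(C(CC/N=C(\N)NCCCc2c[nH]cn2)c2ccccn2)cc1`: 0.5
- compound 2 `N=C(NCCCc1c[nH]cn1)NCCC(c1ccc(F)cc1)c1ccccn1`: 0.8

Compound 2 stands highest of the two numbers. Its nearest neighbour is compound 1, whose reading is lower by an amount beyond the usual scatter, so the order of the two is taken as real, though nothing is shown about how they differ.

Compound 3 `N=C(NCCCc1c[nH]cn1)NCCC(c1ccc(C(F)(F)F)cc1)c1ccccn1` has not yet been measured in this assay. It differs from compound 2 as follows: trifluoromethyl in place of fluoro on an aromatic carbon. Among the compounds with values here, no step between measured compounds bears on this exchange, so the size of its effect can only be guessed. A small move downward from compound 2 is expected, at or just beyond the scatter; a move upward cannot be excluded.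

For compound 3 a step of a number 0.10 lower from compound 2 to compound 3 (within the scatter) is estimated. Compound 3 is therefore expected to give 0.7 in this assay, within a range from 0.5 to 0.9.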

Compound 3, intrinsic activity: the largest response reached, as a fraction of the reference agonist's: 0.9
The estimate for compound 3 lay 0.20 below the measured number, and the stated range covers the measured number.
By their numbers in this assay, from the lowest: compound 1; then compounds 2 and 3 (each within the scatter of the next).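

In this assay the exchange of fluoro for trifluoromethyl, on an aromatic carbon para to a large group, reads as a number 0.10 higher from compound 2 to compound 3 (within the scatter), so compound 2 and compound 3 cannot be told apart. This place on the six-membered aromatic ring therefore accepts a group of 4 heavy atoms in place of one of 1 heavy atom, with no loss of maximal response beyond the scatter. Nothing measured alongside these compounds speaks to why the read-out holds across this exchange.

Open, as far as these compounds go, is whether an amine or a carboxylic acid at this same place would also leave the maximal response intact. Also open, from the compounds shown here alone, is whether the exchange of fluoro for trifluoromethyl would read the same way with a longer chain in the shared core.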